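Two chlorines on the phenyl urea of compound 3

The compounds below may be only part of what the source reports. "The series", "measured", "known", "first", "only" and "open" are said of these compounds alone.

Measured compounds and values:
Compound 1, `Cc1cc(OCc2nc3ccccc3s2)ccc1NC(=O)Nc1ccccc1`: in an assay on isolated protein for inhibition of Polyunsaturated fatty acid 5-lipoxygenase (Homo sapiens), read by HPLC, with a stated time of 10 min (a lower number here means a stronger inhibitor, a higher number a weaker inhibitor), compound 1 gives 730 nM.
Compound 2, `Cc1cc(OCc2nc3ccccc3s2)ccc1NC(=O)Nc1cc(Cl)cc(Cl)c1`: compound 2 gives 80 nM.
Compound 3, `Cc1cc(NC(=O)Nc2ccccc2)ccc1OCc1nc2ccccc2s1`: compound 3 gives 2070 nM.

Compound 3 has the highest number of the three. Its nearest neighbour is compound 1, whose value is lower by a margin beyond the scatter; furthest is compound 2, lower still by a margin well beyond the scatter. Compound 3 is the regioisomer of compound 1, with the urea and the ether exchanged on the shared core.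

Compound 4, `Cc1cc(NC(=O)Nc2ccc(Cl)c(Cl)c2)ccc1OCc1nc2ccccc2s1`, is made from compound 3 by one change: 3,4-dichlorophenyl in place of phenyl on an amide-type nitrogen. For the measured compounds named here, the one measured step that bears on this is a 9.1-fold lower number from compound 1 to compound 2 (0.96 log units; beyond the scatter), where a dichlorophenyl likewise replaced a phenyl on the urea nitrogen, though there with a 3,5-dichloro pattern and on the core of compound 1. That step was modest in size and clearly beyond the scatter. The writer therefore expects compound 4 to give a lower number than compound 3 in this assay, beyond the scatter, while treating the earlier step as a guide rather than a rule, since both the chlorine pattern and the core differ. His estimate for compound 4 is 400 nM, with a range from 150 nM to 1200 nM. The step this estimate implies is a 5.2-fold lower number from compound 3 to compound 4 (0.71 log units; beyond the scatter), and it is an expectation only.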

Compound 4, half-maximal inhibitory concentration: 2170 nM
For compound 4 the middle estimate is 5.4-fold (0.73 log units) below the measured one, and the stated range ends below it.
By their numbers in this assay, from the lowest: compound 2; then compound 1; then compounds 3 and 4 (each within the scatter of the next).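

In this assay the measured result is a 1.0-fold higher number from compound 3 to compound 4 (0.02 log units; within the scatter) for 3,4-dichlorophenyl in place of phenyl on an amide-type nitrogen, so on the core of compound 3 these two chlorines bring no change that can be told from the scatter. The earlier drop of a 9.1-fold lower number from compound 1 to compound 2 (0.96 log units; beyond the scatter) therefore does not hold for every dichlorophenyl urea; it is tied so far to 3,5-dichlorophenyl on the core of compound 1, and the two steps differ in both chlorine pattern and core. No measurement given here bears on why the two steps part ways.

The compounds shown do not tell whether the chlorine pattern or the core separates the two steps, a question that 3,5-dichlorophenyl on the core of compound 3, or 3,4-dichlorophenyl on the core of compound 1, would address directly. They also leave open how this urea position would respond to other groups on the phenyl ring, such as a single chlorine, a methoxy group or a carboxylic acid.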